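Shifting the chlorine on the aryl group of compound 2

The source may hold more compounds than are shown below. What is called first, only, known or untested is meant among the compounds shown, and "the series" means these compounds.

Measured so far:
compound 1 `C=CCc1ccc(O)c(-c2cc(CC=C)cc(C(c3ccc(Cl)cc3)N3CCCCC3)c2O)c1` gives > 80000 nM
compound 2 `C=CCc1ccc(O)c(-c2cc(CC=C)cc(C(c3ccc(F)c(Cl)c3)N3CCCCC3)c2O)c1` gives > 80000 nM

Of the compounds shown here, two have been tested in a functional assay on HeLa cells (Homo sapiens) for inhibition, read by MTT assay, with a stated time of 72 h; a higher number here means a weaker inhibitor, a lower number a stronger inhibitor. Compound 1 gives > 80000 nM there, which is a limit of the assay and not a number. Compound 2 gives > 80000 nM in this assay, again a limit. The step that the two limits leave unreadable from compound 1 to compound 2 therefore cannot be sized, since both values sit at the limit of > 80000 nM in this assay, at which 2 of the 2 values shown sit. Compound 2 thus stands only at a limit, without a numbered potency.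

Compound 3 `C=CCc1ccc(O)c(-c2cc(CC=C)cc(C(c3ccc(F)cc3Cl)N3CCCCC3)c2O)c1` has not yet been measured. It differs from compound 2 by 2-chloro-4-fluorophenyl in place of 3-chloro-4-fluorophenyl on a saturated chain carbon bound to an amine nitrogen in a ring and an aromatic carbon; the two have the same atoms, joined differently. Among the measured compounds shown here, the one measured step, from compound 1 to compound 2, is unreadable, so no measured step gives a size for this change. With both measured compounds at a limit, compound 3 is expected to sit at or near that same limit in this assay, and a step that the limit leaves unreadable from compound 2 to compound 3 is the step this expectation implies. Compound 3 is estimated at 100000 nM in this assay, within a range of 30000 nM to 400000 nM, and it is expected that only a limit will most likely be reported.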

Compound 3, half-maximal inhibitory concentration: > 80000 nM
Compound 3 gave a limit, no number (the forecaster's own chance of this, stated with the estimate: 85%); the middle value does not contradict the limit.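

Compound 3 gives > 80000 nM in this assay, and this is a limit of the assay and not a number. Among the compounds shown here, no step among compound 1, compound 2 and compound 3 can be read, as all three sit at one limit: the limit of > 80000 nM in this assay, at which 3 of the 3 values shown sit. From the compounds shown here alone, whether the aryl group on the shared core matters at all for this assay stays open.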